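The compounds below may be only part of what the source reports. "The series", "measured", "known", "first", "only" and "open" are said of these compounds alone.

Compound 3 `FC(F)(F)c1ccc(-c2cn(Cc3ccccc3)nn2)cc1` sits at the edge of what a functional assay on B16 cells (Mus musculus) for cytotoxicity, read by MTT assay, with a stated time of 48 h (on this read-out higher numbers stand for weaker inhibition and lower numbers for stronger inhibition), can show: in this assay compound 3 gives > 100000 nM, which is a limit and not a number. Compound 1 `COc1ccc(-c2cn(C[C@H]3COC(C)(C)O3)nn2)cc1` also gives > 100000 nM in this assay, again a limit. Compound 2 `CC1(C)OCC(Cn2cc(-c3ccc(C(F)(F)F)cc3)nn2)O1` gives a real number, 13500 nM, in this assay. Two of the three values thus sit at the limit of > 100000 nM in this assay, at which 2 of the 3 values shown sit. Compound 4 `CC1(C)OC[C@H](Cn2cc(-c3ccc(C(F)(F)F)cc3)nn2)O1` differs from compound 3 in one place: 2,2-dimethyl-1,3-dioxolan-4-yl in place of phenyl on a saturated chain carbon bound to an aromatic nitrogen. Within the data shown here, this reverses the one measured step that bears on it, an at least 7.4-fold higher number from compound 2 to compound 3 (0.86 log units; beyond the scatter), which ran beyond the scatter. Because compound 2 gives 13500 nM in this assay, compound 4 is expected to show a step of an at least 7.4-fold lower number from compound 3 to compound 4 (0.86 log units; beyond the scatter). For compound 4 the estimate is 13500 nM, expected between 5000 nM and 40000 nM.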

Compound 4, half-maximal inhibitory concentration: > 100000 nM
Compound 4: no number, only a limit; the forecaster's own chance of this, stated with the estimate: 25%; middle value at least 7.4-fold (0.86 log units) from the limit.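

Placing 2,2-dimethyl-1,3-dioxolan-4-yl on the saturated chain carbon bound to an aromatic nitrogen does not by itself give a measurable value in this assay. The steps to compound 4 from compound 3 and from compound 1 cannot be read, since both ends of each are limits: the limit of > 100000 nM in this assay, at which 3 of the 4 values shown sit. Among these compounds, the one readable step, an at least 7.4-fold higher number from compound 2 to compound 4 (0.86 log units; beyond the scatter), joins two structures with the same atoms and bonds, so it points to the stereocentre at the saturated ring carbon: the fact that one of compounds 2 and 4 is drawn with a defined configuration and the other without, at the place where they differ.

From the compounds shown here alone, what a compound drawn with the opposite configuration would give stays open. So does the effect of an amine or a carboxylic acid on the same chain carbon.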